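The source may report more compounds than this note shows. Statements on the series, on what has been measured and on what is new or still open speak of the compounds shown alone.

Measured compounds in a functional assay on WI-38 VA13 cells (Homo sapiens) for cytotoxicity; a higher number here means that more compound is needed for the effect, a lower number that less compound is needed:
compound 1 `COC(=O)Nc1nc2ccc(NC(=O)c3c(Cl)cccc3Cl)cc2s1`: 0.0095 ug/mL
compound 2 `CCOC(=O)Nc1nc2ccc(NC(=O)c3c(Cl)cccc3Cl)cc2s1`: 0.0026 ug/mL
compound 3 `CC(C)COC(=O)Nc1nc2ccc(NC(=O)c3c(Cl)cccc3Cl)cc2s1`: 0.0035 ug/mL

Compound 3 gives the second highest of the three numbers. Its nearest neighbour is compound 2, a 1.3-fold higher number from compound 2 to compound 3 (0.13 log units; within the scatter), which is within the scatter. Its furthest is compound 1, a 2.7-fold lower number from compound 1 to compound 3 (0.43 log units; beyond the scatter), beyond the scatter.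

Compound 4 `O=C(Nc1nc2ccc(NC(=O)c3c(Cl)cccc3Cl)cc2s1)Oc1ccccc1` differs from compound 3 in one place: phenyl in place of isobutyl on an oxygen next to a carbonyl group.

All three measured steps alter the group on the same oxygen next to the carbonyl group. From hydrogen to a small alkyl the number fell modestly, a 3.7-fold lower number from compound 1 to compound 2 (0.56 log units; beyond the scatter) and a 2.7-fold lower number from compound 1 to compound 3 (0.43 log units; beyond the scatter). Between the two alkyls nothing beyond the scatter was seen, a 1.3-fold higher number from compound 2 to compound 3 (0.13 log units; within the scatter). Among the measured compounds shown here, no compound with an aromatic ring in this place has been measured, so the size of the step to phenyl rests only on the observation that changes among alkyl groups here stayed within the scatter.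

Compound 4 is therefore expected to land close to compound 3, with a step of a 1.1-fold higher number from compound 3 to compound 4 (0.06 log units; within the scatter) that is not expected to exceed the scatter. The estimate for compound 4 in this assay is 0.004 ug/mL, in the range 0.0015 ug/mL to 0.012 ug/mL.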

Compound 4, half-maximal effective concentration: 1.1 ug/mL
The estimate for compound 4 lay 280-fold (2.44 log units) below the measured number; measured number above the stated range.
By their numbers in this assay, from the lowest: compounds 2 and 3 (each within the scatter of the next); then compound 1; then compound 4.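

In this assay, the position on an oxygen next to a carbonyl group turns out to be far less tolerant than the alkyl compounds alone indicated: phenyl in place of isobutyl gives a 310-fold higher number from compound 3 to compound 4 (2.50 log units; beyond the scatter), phenyl in place of ethyl gives a 420-fold higher number from compound 2 to compound 4 (2.63 log units; beyond the scatter), and phenyl in place of methyl gives a 120-fold higher number from compound 1 to compound 4 (2.06 log units; beyond the scatter). The near-equal numbers for ethyl and isobutyl therefore do not extend to every group at this position, and a single replacement here can move the number by much more than any step among the alkyl compounds. Nothing available bears on the cause of this jump.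

The compounds shown do not separate the effect of the aromatic ring from that of the larger group. Benzyl or cyclohexyl on this oxygen would help to distinguish the two.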